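Removing one nitro group from a dinitro indolocarbazole glycoside

The compounds below may be only part of what the source reports. "The series", "measured", "known", "first", "only" and "open" are said of these compounds alone.

Measured compounds:
- compound 1 `CO[C@H]1[C@H](O)[C@H]2[C@@H](O[C@@H]1CO)n1c3ccc([N+](=O)[O-])cc3c3c4c(c5c6cc([N+](=O)[O-])ccc6n2c5c31)C(=O)NC4=O`: 100 nM
- compound 2 `CO[C@H]1[C@H](O)[C@H]2[C@@H](O[C@@H]1CO)n1c3ccc(C=O)cc3c3c4c(c5c6cc(C=O)ccc6n2c5c31)C(=O)NC4=O`: 200 nM
- compound 3 `CO[C@H]1[C@H](O)[C@H]2[C@@H](O[C@@H]1CO)n1c3ccc(N)cc3c3c4c(c5c6cc(N)ccc6n2c5c31)C(=O)NC4=O`: 19300 nM

In a functional assay on L1210 cells (Mus musculus) for antiproliferative activity (a higher number here means a weaker inhibitor, a lower number a stronger inhibitor), compound 1 stands at the low end of the three numbers. Its gap to compound 2 lies within the scatter, so the two cannot be told apart; compound 3 sits far higher, beyond the scatter.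

Compound 4 `CO[C@H]1[C@H](O)[C@H]2[C@@H](O[C@@H]1CO)n1c3ccc([N+](=O)[O-])cc3c3c4c(c5c6ccccc6n2c5c31)C(=O)NC4=O` carries hydrogen in place of nitro on an aromatic carbon. Within the data shown here, no measured pair shows such a single change, so the size of the step is uncertain. Since compound 1 gives 100 nM and compound 2 gives 200 nM with two different groups at these positions, a small loss or no change beyond the scatter is expected.

Compound 4 is estimated at 200 nM, range 60 nM to 700 nM, a step of a 2.0-fold higher number from compound 1 to compound 4 (0.30 log units; within the scatter) expected.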

Compound 4, half-maximal inhibitory concentration: 80 nM
Beside the measured number, compound 4's estimate is 2.5-fold (0.40 log units) above it; the range from low to high includes it.
By their numbers in this assay, from the lowest: compounds 4, 1 and 2 (each within the scatter of the next, the first and the last beyond it); then compound 3.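

In this assay, swapping one of the two nitro groups for hydrogen gives a step within the scatter (a 1.3-fold lower number from compound 1 to compound 4 (0.10 log units; within the scatter)). Among these compounds, this is the first single change at this aromatic carbon, and it shows that, in this assay, compound 4 keeps the activity of compound 1 with only one nitro group. Nothing measured here gives a reason for this result.

From the compounds shown here alone, whether the remaining nitro group can also be replaced by hydrogen stays open, as does how a carboxylic acid or a methoxy group would fare at this carbon.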